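This account rests on a few compounds, and the source may have more. Where it says the series, first, only, none or still open, it means among the compounds named here.

Working notes on the series, read in an ADME assay on MT4 cells (Homo sapiens) for cytotoxicity, read by MTT assay, with a stated time of 96 h; a lower number here means that less compound is tolerated, a higher number that more compound is tolerated. Compound 3 `c1ccc(/N=N/N2CCCC2)cc1`, which carries hydrogen on the aromatic carbon in question, gives only a limit, > 100000 nM. Compound 2 `O=[N+]([O-])c1ccc(/N=N/N2CCCC2)cc1`, the nitro member, also gives only a limit, >= 100000 nM. Going by the values given here, compound 1 `COc1ccc(/N=N/N2CCCC2)cc1`, the methoxy member, is the only one with a measured number, 68000 nM.

The next step leads to compound 4 `Brc1ccc(/N=N/N2CCCC2)cc1`, with bromo in place of hydrogen on an aromatic carbon. Among the compounds with values here, three measured steps bear on it, all exchanges on an aromatic carbon. Nitro in place of methoxy gives an at least 1.4-fold higher number from compound 1 to compound 2 (0.16 log units; that floor lies within the scatter). Hydrogen in place of methoxy gives an at least 1.4-fold higher number from compound 1 to compound 3 (0.16 log units; that floor lies within the scatter). Hydrogen in place of nitro gives a step that the two limits leave unreadable from compound 2 to compound 3. None of the three is shown to lie beyond the scatter, so these steps give no firm size for a new exchange at this carbon.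

In this assay, a small move towards a lower number is expected, or none beyond the scatter, with compound 1 at 68000 nM as the only numerical anchor. The expected step is an at least 1.3-fold lower number from compound 3 to compound 4 (0.12 log units; that floor lies within the scatter). For compound 4 the estimated value is 75000 nM, with an expected range from 30000 nM to 150000 nM.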

Compound 4, half-maximal cytotoxic concentration: > 100000 nM
Compound 4: a limit, no number; the forecaster's own chance of this, stated with the estimate: 45%; middle value at least 1.3-fold (0.12 log units) away from the limit.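

In this assay, going by these compounds alone, bromo on the aromatic carbon para to a group of 7 heavy atoms joins hydrogen and nitro in giving only a limit, so compound 1, the methoxy member, remains the only one with a number. Bromo in place of methoxy gives an at least 1.4-fold higher number from compound 1 to compound 4 (0.16 log units; that floor lies within the scatter), so a third exchange away from methoxy at this carbon also shows no difference beyond the scatter. The steps to compound 4 from compound 3 and from compound 2 cannot be read, because both ends of each pair are limits: the limit of > 100000 nM in this assay, at which 2 of the 4 values shown sit.

From the compounds shown here alone, how the hydrogen, nitro and bromo members stand relative to one another remains open, with compound 2 resting on a limit of its own: the limit of >= 100000 nM in this assay, at which 1 of the 4 values shown sits. Also open is whether an amine, a carboxylic acid or a longer chain at this carbon would give a number, as methoxy does in compound 1, and whether any exchange here would move the value beyond the scatter.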